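The compounds below may be only part of what the source reports. "The series", "measured", "known", "first", "only" and "open" are said of these compounds alone.

Measured compounds:
- compound 1, `N#Cc1ccc(C(c2ccc3cc[nH]c3c2)n2ccnc2)cc1`, in an assay on microsomes from placenta for inhibition of Aromatase (Homo sapiens) (on this read-out lower numbers stand for stronger inhibition and higher numbers for weaker inhibition), compound 1 gives 11.5 nM
- compound 2, `N#Cc1ccc(C(c2cccc3[nH]ccc23)n2ccnc2)cc1`, in this assay compound 2 gives 18.7 nM

Compound 2 stands as the higher of the two numbers, but its nearest neighbour, compound 1, lies within the scatter of it, so the two read as equal on this assay.

Compound 3, `N#Cc1ccc(C(c2cccc3[nH]ccc23)n2cncn2)cc1`, is not yet measured. It differs from compound 2 by 1H-1,2,4-triazol-1-yl in place of 1H-imidazol-1-yl on a saturated chain carbon bound to two aromatic carbons. Among the compounds with values here, no step of this kind occurs between measured compounds, so nothing in the two numbers shows how this assay responds to it. Among five-membered azoles on such a carbon the shift is often modest; a small loss, or a step not beyond the scatter, is the expectation here. Compound 3 is estimated at 35 nM, with a range from 12 nM to 100 nM. The step this implies, a 1.9-fold higher number from compound 2 to compound 3 (0.27 log units; within the scatter), is an estimate, not a measurement.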

Compound 3, half-maximal inhibitory concentration: 1620 nM
Estimate against measurement, compound 3: 46-fold (1.67 log units) below, and the stated range ends below it.
By their numbers in this assay, from the lowest: compounds 1 and 2 (each within the scatter of the next); then compound 3.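

In this assay the azole on the saturated chain carbon bound to two aromatic carbons proves a sensitive place: 1H-1,2,4-triazol-1-yl in place of 1H-imidazol-1-yl gives an 87-fold higher number from compound 2 to compound 3 (1.94 log units; beyond the scatter) and so a large loss of inhibition. The two groups hold the same count of heavy atoms and differ by one ring carbon exchanged for a nitrogen, so a change this small in atom count is enough to move the read-out well beyond the scatter. Nothing at hand bears on what lies behind the size of this step.

Open, from the compounds shown here alone, is whether the same exchange on the core of compound 1 gives a step of similar size. Also open, going by these compounds, is how other rings on this carbon read, such as 1H-tetrazol-1-yl or pyridin-3-yl, and so whether the imidazole stands alone here.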